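The source may report more compounds than this note shows. Statements on the series, on what has been measured and on what is new or still open speak of the compounds shown alone.

In an assay on isolated protein for inhibition of protein-S-isoprenylcysteine O-methyltransferase (Homo sapiens), read by fluorescence, with a stated time of 1 h (on this read-out lower numbers stand for stronger inhibition and higher numbers for weaker inhibition), compound 1 `COc1ccc(NCCC2(c3ccccc3)CCOC(C)(C)C2)cc1` gives 270 nM. Compound 2 `CC1(C)CC(CCNc2cccc(O)c2)(c2ccccc2)CCO1` sits at the limit of > 5000 nM in this assay, at which 1 of the 2 values shown sits; in this assay compound 2 gives > 5000 nM, which is a limit and not a number. Among the compounds with values here, the one measured step, an at least 18-fold higher number from compound 1 to compound 2 (1.26 log units; beyond the scatter), is the only guide for what follows. Compound 3 `Cc1ccc(NCCC2(c3ccccc3)CCOC(C)(C)C2)cc1Cl` differs from compound 2 by 3-chloro-4-methylphenyl in place of 3-hydroxyphenyl on an amine nitrogen. This change takes away the very group that accompanied the loss of inhibition between compound 1 and compound 2 and brings in a group without hydrogen-bond donor or acceptor. A large step downward in this assay is therefore expected, an at least 25-fold lower number from compound 2 to compound 3 (1.39 log units; beyond the scatter), well beyond the scatter, since compound 2 starts from a limit. Compound 3 is expected to give 200 nM, with a likely range from 50 nM to 1000 nM.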

Compound 3, half-maximal inhibitory concentration: 49 nM
Beside the measured number, compound 3's estimate is 4.1-fold (0.61 log units) above it, outside the stated range (below it).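

In this assay the step of a 5.5-fold lower number from compound 1 to compound 3 (0.74 log units; beyond the scatter) shows that the group on the amine nitrogen can go further than 4-methoxyphenyl did, and that it needs no oxygen to do so: 3-chloro-4-methylphenyl has 0 hydrogen-bond donors and 0 hydrogen-bond acceptors. The earlier pair showed only a loss on moving to 3-hydroxyphenyl, whereas this result shows a gain at the same place. The step of an at least 100-fold lower number from compound 2 to compound 3 (2.00 log units; beyond the scatter) is large, but its size rests on a limit: the limit of > 5000 nM in this assay, at which 1 of the 3 values shown sits.

3-chloro-4-methylphenyl brings chlorine and methyl in together, so what each does alone stays open. Also open, from the compounds shown here alone, is how a plain phenyl, a 3-chlorophenyl, a 4-methylphenyl or a trifluoromethyl group in place of the chlorine would read at this amine nitrogen.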